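Chain extension from compound 3 to compound 4

This account rests on a few compounds, and the source may have more. Where it says the series, first, only, none or still open, it means among the compounds named here.

Measured in a functional assay on the whole organism (blood, strain albino) with Mus musculus as the target, with stated times of 6 days and 4 h, at a dose of 0.4 mmol/kg by the oral route; on this read-out higher numbers stand for more inhibition at the one dose given (going by the name of the read-out) and lower numbers for less inhibition:
compound 1, `Cc1cc(C)n(-c2ccc(S(=O)(=O)NC(=S)NCc3ccccc3)cc2)n1`, gives 0%.
compound 2, `CCCCNC(=O)NS(=O)(=O)c1ccc(-n2nc(C)cc2C)cc1`, gives 2%.
compound 3, `CCNC(=S)NS(=O)(=O)c1ccc(-n2nc(C)cc2C)cc1`, gives 0%.

Compound 3 shows no inhibition at the dose given; its number sits within the scatter of both compound 1 and compound 2, so the three measured compounds cannot be told apart in this assay.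

Compound 4, `CCCCNC(=S)NS(=O)(=O)c1ccc(-n2nc(C)cc2C)cc1`, differs from compound 3 by ethyl in place of hydrogen on a saturated chain carbon, two bonds along the chain from an amide-type nitrogen. Among the measured compounds shown here, two measured steps bear on it: a number 2 percentage points lower from compound 2 to compound 3 (within the scatter), which changes the same chain, and no change at the digits printed from compound 1 to compound 3 (within the scatter). Neither moved beyond the scatter, so no change beyond the scatter is expected in this assay: a number 1 percentage points higher from compound 3 to compound 4 (within the scatter). Compound 4 is estimated at 1%, between 0% and 10%.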

Compound 4, a percentage reported as inhibition, in the whole organism at one dose (the size of the read-out at that dose, not a potency): 1%
Compound 4: the middle estimate sits on the measured number at the digits printed, and the stated range covers the measured number.
By their numbers in this assay, from the lowest: compounds 1, 3, 4 and 2 (each within the scatter of the next).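

With the thiocarbonyl side held fixed, ethylamino to butylamino gives a number 1 percentage points higher from compound 3 to compound 4 (within the scatter) in this assay. Among the compounds shown here, with butyl held fixed, sulfur in place of oxygen gives a number 1 percentage points lower from compound 2 to compound 4 (within the scatter), the first step here that isolates this exchange. Propyl in place of phenyl gives a number 1 percentage points higher from compound 1 to compound 4 (within the scatter), so neither the chain length, the oxygen-sulfur exchange nor the phenyl end separates these compounds at this dose. Nothing available bears on why the numbers stay this low. Open, on these data alone, is whether a chain longer than butyl, or an amine or a carboxylic acid at its end, would give a number beyond the scatter.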